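A (methylsulfonyl)methyl group carried over to a second core

The compounds below may be only part of what the source reports. "The series", "measured", "known", "first", "only" and "open" are said of these compounds alone.

Compound 2 `Oc1cccc(-c2nccc(C3=CCOCC3)n2)c1` gives 3.6 in a physicochemical assay for lipophilicity; a higher number here means a more lipophilic compound, a lower number a more polar compound. Compound 1 `CS(=O)(=O)Cc1cc(C2=CCOCC2)nc(-c2cccc(O)c2)n1` carries one more group on the shared core: (methylsulfonyl)methyl in place of hydrogen on an aromatic carbon. In this assay compound 1 gives 3.3. That gave the step of a number 0.30 log units lower from compound 2 to compound 1 (within the scatter). Compound 3 `CCNC(=O)Nc1ccc(-c2nccc([C@@]34CCOC[C@@H]3C4)n2)cc1` is built on a different core, and the difference between the two cores is not broken down here; in this assay compound 3 gives 3.9. Compound 4 `CCNC(=O)Nc1ccc(-c2nc(CS(C)(=O)=O)cc([C@@]34CCOC[C@@H]3C4)n2)cc1` has not been measured yet. It differs from compound 3 by the same kind of change: (methylsulfonyl)methyl in place of hydrogen on an aromatic carbon. The surroundings of the place are not identical: in compound 1 the new group sits meta to a 3-hydroxyphenyl group (7 heavy atoms) and meta to a group of 6 heavy atoms, while in compound 4 it sits meta to a group of 7 heavy atoms and meta to a large group. The change appears only twice among these compounds, so the expected step of a number 0.30 log units lower from compound 3 to compound 4 (within the scatter) is set beside the one measured case, the step of a number 0.30 log units lower from compound 2 to compound 1 (within the scatter). Compound 4 is therefore expected to give about 3.6 in this assay, with a likely range from 3.2 to 4.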

Compound 4, partition coefficient: 3.6
Beside the measured number, compound 4's estimate shows no gap at the digits printed; the measured number falls inside the stated range.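

In this assay the swap of hydrogen for (methylsulfonyl)methyl on an aromatic carbon now reads as a number 0.30 log units lower from compound 3 to compound 4 (within the scatter) and, on the other core, as a number 0.30 log units lower from compound 2 to compound 1 (within the scatter) so the two steps are the same size. This shows that the change gave no step beyond the scatter on either core, but it does not show that the group truly shifts this number, and two cases make no rule for the whole series. No measurement shown here explains why the two steps match.

Only hydrogen and (methylsulfonyl)methyl appear at this place, so the compounds shown leave open how an amine, a carboxylic acid or a longer chain such as (ethylsulfonyl)methyl would read there in this assay on either core. They also leave open whether the step would stay this size on a third core.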